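From chloro to bromo on a shared core

The compounds below may be only part of what the source reports. "The series", "measured", "known", "first", "only" and "open" are said of these compounds alone.

Of the compounds shown here, three sharing one core have been tested in a functional assay on MCF7 cells (Homo sapiens) for inhibition (a lower number here means a stronger inhibitor, a higher number a weaker inhibitor), and they differ only in the group on one aromatic carbon. Compound 1 `O=C1O/C(=C\Cn2cc(C(F)(F)F)c(=O)[nH]c2=O)C(OCc2ccccc2)=C1OCc1ccccc1`, which carries trifluoromethyl, gives 40000 nM. Compound 2 `O=C1O/C(=C\Cn2ccc(=O)[nH]c2=O)C(OCc2ccccc2)=C1OCc1ccccc1`, which carries hydrogen, gives 20000 nM. Compound 3 `O=C1O/C(=C\Cn2cc(Cl)c(=O)[nH]c2=O)C(OCc2ccccc2)=C1OCc1ccccc1`, which carries chloro, gives 60000 nM. This value cannot be told apart from that of the trifluoromethyl analogue, as the measured step is a 1.5-fold higher number from compound 1 to compound 3 (0.18 log units; within the scatter). The hydrogen analogue does stand apart, with a 3.0-fold higher number from compound 2 to compound 3 (0.48 log units; beyond the scatter). The remaining step, a 2.0-fold lower number from compound 1 to compound 2 (0.30 log units; within the scatter), again stays within normal variation.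

Compound 4 `O=C1O/C(=C\Cn2cc(Br)c(=O)[nH]c2=O)C(OCc2ccccc2)=C1OCc1ccccc1` has bromo in place of chloro on that same aromatic carbon: bromo in place of chloro on an aromatic carbon. Among the compounds with values here, no bromo compound has been measured yet, so the guide is how much this position has mattered so far. The largest change seen, a 3.0-fold higher number from compound 2 to compound 3 (0.48 log units; beyond the scatter), is only modest, and it involves removing the halogen altogether. Exchanging one group for another, as in a 1.5-fold higher number from compound 1 to compound 3 (0.18 log units; within the scatter), produced nothing beyond the scatter. A swap of one halogen for another is therefore expected to leave this assay essentially unmoved. The expected step is a 1.2-fold lower number from compound 3 to compound 4 (0.08 log units; within the scatter), with no real change in either direction. Compound 4 is estimated at 50000 nM, with an expected range from 20000 nM to 100000 nM.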

Compound 4, half-maximal inhibitory concentration: 40000 nM
Beside the measured number, compound 4's estimate is 1.3-fold (0.10 log units) above it; low and high end bracket the measured number.
By their numbers in this assay, from the lowest: compounds 2, 1, 4 and 3 (each within the scatter of the next, the first and the last beyond it).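

In this assay, exchanging chloro for bromo gives a 1.5-fold lower number from compound 3 to compound 4 (0.18 log units; within the scatter), so replacing one of these halogens with the other on this aromatic carbon produces no change that can be told apart from ordinary variation. The new compound also puts the earlier hydrogen-to-chloro difference in context: a 2.0-fold higher number from compound 2 to compound 4 (0.30 log units; within the scatter) shows that bromo, unlike chloro, cannot be distinguished from hydrogen, so adding a halogen at this position does not reliably produce a step beyond the scatter. Compared with trifluoromethyl, there is no change at the digits printed from compound 1 to compound 4 (within the scatter), which places compound 4 within the scatter of every other compound in the set and leaves the difference between compound 2 and compound 3 as the only one beyond it.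

No supporting measurement is available to explain these small differences. The compounds shown leave open whether a different kind of group on this carbon, such as an amine, a carboxylic acid or a longer chain, would move the number much further than the groups compared here.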